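A few compounds are considered here, and "the series" means these few. Any claim that something is new, unique, unknown or untested is made for them only; others in the source may bear on it.

Measured so far in a functional assay on T47D cells (Homo sapiens) for cytotoxicity, read by sulforhodamine B assay, with a stated time of 48 h; on this read-out lower numbers stand for stronger inhibition and higher numbers for weaker inhibition:
compound 1 `Cc1ccnc(NS(=O)(=O)c2ccc(N/C=C\C(=O)c3cc4ccccc4oc3=O)cc2)n1`, 24500 nM;
compound 2 `Cc1cc(NS(=O)(=O)c2ccc(N/C=C\C(=O)c3cc4ccccc4oc3=O)cc2)nc(C)n1`, 100000 nM;
compound 3 `COc1cnc(NS(=O)(=O)c2ccc(N/C=C\C(=O)c3cc4ccccc4oc3=O)cc2)nc1`, 8800 nM.

Compound 3 stands lowest of the three, since a 2.8-fold lower number from compound 1 to compound 3 (0.44 log units; beyond the scatter) and an 11-fold lower number from compound 2 to compound 3 (1.06 log units; beyond the scatter) both lie beyond the scatter, while a 4.1-fold higher number from compound 1 to compound 2 (0.61 log units; beyond the scatter) runs the other way. Compound 4 `O=C(/C=C\Nc1ccc(S(=O)(=O)Nc2cnc3ccccc3n2)cc1)c1cc2ccccc2oc1=O` is not yet measured and differs from compound 3 in one place: quinoxalin-2-yl in place of 5-methoxypyrimidin-2-yl on a sulfonamide nitrogen. Among the measured compounds shown here, none of the three measured steps brings in a fused two-ring group, so they give no direct precedent; they only show that swapping the group on the sulfonamide nitrogen moves the number by modest to large amounts. A modest rise, with wide uncertainty, is the expectation. Compound 4 is therefore estimated at 18000 nM, between 5000 nM and 60000 nM, meaning an expected step of a 2.0-fold higher number from compound 3 to compound 4 (0.31 log units; beyond the scatter).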

Compound 4, half-maximal inhibitory concentration: 86900 nM
For compound 4 the middle estimate is 4.8-fold (0.68 log units) below the measured one, and the stated range ends below it.
By their numbers in this assay, from the lowest: compound 3; then compound 1; then compounds 4 and 2 (each within the scatter of the next).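

Moving to quinoxalin-2-yl, the first group here with two rings, on a sulfonamide nitrogen in this assay gives a 9.9-fold higher number from compound 3 to compound 4 (0.99 log units; beyond the scatter) and so loses the edge held by 5-methoxypyrimidin-2-yl. The same group also gives a 3.5-fold higher number from compound 1 to compound 4 (0.55 log units; beyond the scatter) against 4-methylpyrimidin-2-yl, whereas a 1.2-fold lower number from compound 2 to compound 4 (0.06 log units; within the scatter) is within the scatter, so compound 4 and compound 2 cannot be told apart. No measurement at hand explains these steps.

As far as these compounds go, it remains open whether a plain phenyl, or a quinoxalin-2-yl carrying a methoxy group, would behave the same way on this nitrogen.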